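This account rests on a few compounds, and the source may have more. Where it says the series, first, only, none or still open, it means among the compounds named here.

Working notes on the series.

Compound 1 `C=C(C)[C@@H]1CC=C(Cn2cc(COc3ccc(C4NC(=O)NC(C)=C4C(C)=O)cc3)nn2)CC1` is the reference point. In an ADME assay on HaCaT cells (Homo sapiens) for inhibition, read by sulforhodamine B assay, with a stated time of 48 h (a higher number here means a weaker inhibitor of growth, a lower number a stronger inhibitor of growth), compound 1 gives 44500 nM. Compound 2 `C=C(C)[C@@H]1CC=C(Cn2cc(COc3ccc(C4NC(=O)NC(C)=C4C(C)=O)cc3OC)nn2)CC1` carries the change (methoxy in place of hydrogen on an aromatic carbon); in this assay compound 2 gives 148000 nM, and the step is a 3.3-fold higher number from compound 1 to compound 2 (0.52 log units; beyond the scatter). Compound 3 `C=C(C)[C@@H]1CC=C(Cn2cc(COc3cccc(C4NC(=O)NC5=C4C(=O)CC(C)(C)C5)c3)nn2)CC1` has a different core; how the core of compound 3 differs from the core of compound 1 is not broken down here. In this assay compound 3 gives 36400 nM, which lies within the scatter of the number for compound 1, so no order between compound 1 and compound 3 can be read from these two values.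

Compound 4 `C=C(C)[C@@H]1CC=C(Cn2cc(COc3cc(C4NC(=O)NC5=C4C(=O)CC(C)(C)C5)ccc3OC)nn2)CC1` is not yet measured. It differs from compound 3 by methoxy in place of hydrogen on an aromatic carbon. For the measured compounds named here, this is the same kind of change as the one from compound 1 to compound 2, not the same: the place of the methoxy in compound 2 is ortho to a large group and meta to a large group, whereas in compound 4 it is ortho to a large group and para to a large group. Going by the values given here, with only one measured example of this change, the expectation rests on that pair alone. Among the compounds with values here, a step of roughly comparable size is expected from compound 3 to compound 4, a 2.5-fold higher number from compound 3 to compound 4 (0.39 log units; beyond the scatter), because a 3.3-fold higher number from compound 1 to compound 2 (0.52 log units; beyond the scatter) is the only guide available, tempered somewhat for the different core and the different place. For compound 4 in this assay the estimate is 90000 nM, with a range from 40000 nM to 200000 nM expected.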

Compound 4, concentration for total growth inhibition: 451000 nM
Compound 4: the middle estimate sits 5.0-fold (0.70 log units) below what was measured; measured number outside the range, above it.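

Methoxy in place of hydrogen on an aromatic carbon gives a higher number on both cores in this assay, with a 12-fold higher number from compound 3 to compound 4 (1.09 log units; beyond the scatter) on the core of compound 3, so the direction of the step carries over in these two pairs but its size does not: the same change on two cores in this assay, a 3.3-fold higher number (0.52 log units; beyond the scatter) from compound 1 to compound 2 and a 12-fold higher number (1.09 log units; beyond the scatter) from compound 3 to compound 4, 3.7-fold (0.57 log units) apart, beyond the scatter of two such steps

The two pairs differ in the core and also in where the methoxy sits on the aromatic ring, so the gap between the steps cannot be assigned to either difference alone. With one pair on each core, the result shows that a step measured on one core is a poor guide to the size of the step on the other, but it gives neither a cause for the gap nor a rule for any further core.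

On these data alone, it remains open whether the methoxy would give a step of the size seen on the core of compound 1 or the size seen on the core of compound 3 if it stood in the same place on both cores. As far as these compounds go, it is also open whether a hydroxyl or an ethoxy in that place would follow the methoxy in direction and size.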